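A shorter urea link with a trifluoromethylphenyl end

This account rests on a few compounds, and the source may have more. Where it says the series, first, only, none or still open, it means among the compounds named here.

Compound 1, `COc1cc(NC(C)CCCNC(=O)NNC(=O)Nc2cccc(F)c2)c2ncccc2c1`, in a functional assay on MOLT-4 cells (Homo sapiens) for inhibition, read by MTT assay, with a stated time of 72 h (on this read-out lower numbers stand for stronger inhibition and higher numbers for weaker inhibition), reaches only the limit >= 250000 nM.
Compound 2, `COc1cc(NC(C)CCCNC(=O)NNC(=O)Nc2cc(C(F)(F)F)cc(C(F)(F)F)c2)c2ncccc2c1`, gives 22000 nM in this assay.
Compound 3, `COc1cc(NC(C)CCCNC(=O)NNC(=O)Nc2ccc(O)cc2)c2ncccc2c1`, gives 104000 nM in this assay.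

Among the two numbers, compound 3 stands highest; the nearest, compound 2, sits a step lower that is beyond the scatter. Within the data shown here, the one measured step, an at least 2.4-fold lower number from compound 1 to compound 3 (0.38 log units; beyond the scatter), concerns an aryl swap, and the limit of >= 250000 nM in this assay, at which 1 of the 3 values shown sits, sets the floor for that step. Compound 4, `COc1cc(NC(C)CCCNC(=O)Nc2cccc(C(F)(F)F)c2)c2ncccc2c1`, differs from compound 3 as follows: 3-(trifluoromethyl)phenyl in place of ((4-hydroxyphenyl)carbamoyl)amino on an amide-type nitrogen. Among the measured compounds shown here, no measured step covers this change, so the expectation leans only on compound 2, whose trifluoromethyl-bearing aryl gives 22000 nM. Compound 4 is therefore expected to land at 40000 nM, between 10000 nM and 200000 nM, an estimated step of a 2.6-fold lower number from compound 3 to compound 4 (0.41 log units; beyond the scatter).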

Compound 4, half-maximal inhibitory concentration: 20000 nM
Compound 4: the middle estimate sits 2.0-fold (0.30 log units) above what was measured; the measured number falls inside the stated range.
By their numbers in this assay, from the lowest: compounds 4 and 2 (each within the scatter of the next); then compound 3. At a limit, above all of these: compound 1.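

In this assay, among these compounds, the earlier compounds changed only the aryl end of the longer link, whereas here the shorter urea link also holds up: 3-(trifluoromethyl)phenyl in place of ((4-hydroxyphenyl)carbamoyl)amino on an amide-type nitrogen gives a 5.2-fold lower number from compound 3 to compound 4 (0.72 log units; beyond the scatter). The matching replacement of ((3-fluorophenyl)carbamoyl)amino gives an at least 12-fold lower number from compound 1 to compound 4 (1.09 log units; beyond the scatter). That second step rests on a limit for compound 1: the limit of >= 250000 nM in this assay, at which 1 of the 4 values shown sits.

Both steps change the link and the aryl end together, so the compounds shown do not separate the two. Also open, going by these compounds, is how an amine or a carboxylic acid in place of trifluoromethyl would read in this assay.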